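Furan carboxamide series: methyl for chloro on the phenol ring

The source may hold more compounds than are shown below. What is called first, only, known or untested is meant among the compounds shown, and "the series" means these compounds.

Measured so far in an assay on T47D cells for inhibition of 17-beta-hydroxysteroid dehydrogenase type 1 (Homo sapiens), read by HPLC, with a stated time of 24 h; on this read-out higher numbers stand for weaker inhibition and lower numbers for stronger inhibition:
compound 1 `Cc1ccccc1N(C)C(=O)c1ccc(-c2ccc(O)cc2)o1`: 21 nM
compound 2 `Cc1ccccc1N(C)C(=O)c1ccc(-c2cccc(O)c2)o1`: 29 nM
compound 3 `Cc1ccccc1N(C)C(=O)c1ccc(-c2ccc(O)c(Cl)c2)o1`: 52 nM

Compound 3 stands at the highest of the three numbers. Its nearest neighbour is compound 2, and that step, a 1.8-fold higher number from compound 2 to compound 3 (0.25 log units; within the scatter), lies within the scatter. The step from the parent, a 2.5-fold higher number from compound 1 to compound 3 (0.39 log units; beyond the scatter), is the only one among the three that reaches beyond the scatter, and it is modest. The step of a 1.4-fold higher number from compound 1 to compound 2 (0.14 log units; within the scatter) is within the scatter.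

Compound 4 `Cc1cc(-c2ccc(C(=O)N(C)c3ccccc3C)o2)ccc1O` differs from compound 3 in one place: methyl in place of chloro on an aromatic carbon. The change is methyl in place of chloro on an aromatic carbon, ortho to a hydroxy group and meta to a large group.

Going by the values given here, only one measured step touches this carbon: a 2.5-fold higher number from compound 1 to compound 3 (0.39 log units; beyond the scatter), which shows that placing chloro there in place of hydrogen gives a modestly higher number. Among the compounds with values here, no measured pair shows methyl at this carbon, so a swap of one single-heavy-atom group for another there has no direct precedent. Compound 4 is therefore expected to sit close to compound 3, with the step of a 1.3-fold lower number from compound 3 to compound 4 (0.11 log units; within the scatter) expected to stay within the scatter. For compound 4 the estimated value in this assay is 40 nM, with an expected range from 15 nM to 110 nM.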

Compound 4, half-maximal inhibitory concentration: 8.6 nM
Beside the measured number, compound 4's estimate is 4.7-fold (0.67 log units) above it; measured number below the stated range.
By their numbers in this assay, from the lowest: compound 4; then compounds 1, 2 and 3 (each within the scatter of the next, the first and the last beyond it).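

In this assay, this carbon ortho to a hydroxy group proves sensitive to which single heavy atom it carries: replacing chloro with methyl, with no change in heavy-atom or hydrogen-bond counts, gives a 6.0-fold lower number from compound 3 to compound 4 (0.78 log units; beyond the scatter). The earlier compounds shown here showed only a rise on adding chloro, a 2.5-fold higher number from compound 1 to compound 3 (0.39 log units; beyond the scatter), whereas methyl in place of hydrogen moves the number the other way, a 2.4-fold lower number from compound 1 to compound 4 (0.39 log units; beyond the scatter), so substitution at this carbon carries no uniform penalty across these two groups. Compound 4 also clears the 3-hydroxyphenyl analogue, a 3.4-fold lower number from compound 2 to compound 4 (0.53 log units; beyond the scatter), and with all three of its steps beyond the scatter it is the most potent of the four compounds in this assay.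

What separates methyl from chloro at this carbon remains open, as nothing available here bears on the reason for the difference. Also open, as far as these compounds go, is whether the lower number extends to an ethyl chain, a methoxy group or an amine at the same carbon, or whether it belongs to methyl alone.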